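This account rests on a few compounds, and the source may have more. Where it says the series, first, only, none or still open, it means among the compounds named here.

In a functional assay on SKW3 cells (Homo sapiens) for antiproliferative activity, read by WST assay, with a stated time of 3 days (on this read-out higher numbers stand for weaker inhibition and lower numbers for stronger inhibition), compound 1 `O=c1cc(I)n([C@@H]2O[C@H](CO)[C@@H](O)[C@H]2O)c(=O)[nH]1` gives 18900 nM. Compound 2 `[N-]=[N+]=Nc1cc(=O)[nH]c(=O)n1[C@@H]1O[C@H](CO)[C@@H](O)[C@H]1O` gives > 50000 nM, which is a limit. Compound 3 `O=c1[nH]c(=O)n([C@@H]2O[C@H](CO)[C@@H](O)[C@H]2O)c(I)c1F` gives > 50000 nM, also a limit, so it has no number of its own; this is the limit of > 50000 nM in this assay, at which 2 of the 3 values shown sit. Compound 4 `[N-]=[N+]=Nc1c(F)c(=O)[nH]c(=O)n1[C@@H]1O[C@H](CO)[C@@H](O)[C@H]1O` differs from compound 3 by azido in place of iodo on an aromatic carbon. The same exchange gave an at least 2.6-fold higher number from compound 1 to compound 2 (0.42 log units; beyond the scatter), and fluoro in place of hydrogen gave an at least 2.6-fold higher number from compound 1 to compound 3 (0.42 log units; beyond the scatter). From the compounds shown here alone, both steps run towards higher numbers and both end in a limit, so their full size is unknown. The expected change is therefore a further move towards weaker inhibition, estimated as a step that the limit leaves unreadable from compound 3 to compound 4. For compound 4 the estimate is 60000 nM, with an expected range of 30000 nM to 150000 nM.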

Compound 4, half-maximal inhibitory concentration: 400 nM
The estimate for compound 4 lay 150-fold (2.18 log units) above the measured number; the whole stated range lies above it.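

In this assay, azido in place of iodo on the aromatic carbon ortho to a fluoro group gives an at least 120-fold lower number from compound 3 to compound 4 (2.09 log units; beyond the scatter), so this exchange does not act in one direction across the series: the same change on two cores in this assay, an at least 2.6-fold higher number (0.42 log units; beyond the scatter) from compound 1 to compound 2 and an at least 120-fold lower number (2.09 log units; beyond the scatter) from compound 3 to compound 4, at least 330-fold (2.51 log units) apart, beyond the scatter of two such steps Fluoro in place of hydrogen gives an at least 120-fold lower number from compound 2 to compound 4 (2.09 log units; beyond the scatter), so within these compounds the outcome of each change depends on the other: the same change on two cores in this assay, an at least 2.6-fold higher number (0.42 log units; beyond the scatter) from compound 1 to compound 3 and an at least 120-fold lower number (2.09 log units; beyond the scatter) from compound 2 to compound 4, at least 330-fold (2.51 log units) apart, beyond the scatter of two such steps Both steps start from a limit, so their full size cannot be read: the limit of > 50000 nM in this assay, at which 2 of the 4 values shown sit.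

From the compounds shown here alone, whether an amine or a longer chain in place of azido keeps this gain remains open. So does whether chloro in place of fluoro supports it.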